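Cytotoxicity of bornane-derived thiophene amines on canine kidney cells

The source may hold more compounds than are shown below. What is called first, only, known or untested is meant among the compounds shown, and "the series" means these compounds.

Compound 1 `C=C(C)c1csc(CN[C@@H]2C[C@H]3C[C@@H]([C@H]2C)C3(C)C)c1` was examined in an ADME assay on MDCK cells (Canis lupus familiaris) for cytotoxicity, read by microscopy, with a stated time of 48 h (on this read-out higher numbers stand for lower toxicity in this test and lower numbers for higher toxicity in this test), where compound 1 gives 25000 nM. Compound 2 `C[C@H]1[C@H](NCc2sccc2C2CC2)C[C@H]2C[C@@H]1C2(C)C` gives 25000 nM in this assay, level with compound 1 at the digits shown, and compound 3 `C[C@H]1[C@H](NCc2ccsc2)C[C@H]2C[C@@H]1C2(C)C` gives 50000 nM, a difference from compound 1 that stays within the usual scatter; the three numbers thus cannot be told apart. Compound 4 `C[C@H]1[C@H](NCc2cc(-c3ccccc3)cs2)C[C@H]2C[C@@H]1C2(C)C` has not been measured. Its change from compound 1 is phenyl in place of 1-methylethenyl on an aromatic carbon. For the measured compounds named here, with no step between measured compounds to lean on, and the three values already indistinguishable, no step beyond the scatter is expected; compound 4 is estimated at 20000 nM (range 6000 nM to 50000 nM), corresponding to an expected step of a 1.3-fold lower number from compound 1 to compound 4 (0.10 log units; within the scatter).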

Compound 4, minimum cytotoxic concentration: 5000 nM
Beside the measured number, compound 4's estimate is 4.0-fold (0.60 log units) above it, and the stated range ends above it.
By their numbers in this assay, from the lowest: compound 4; then compounds 1, 2 and 3 (each within the scatter of the next).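

In this assay, for the compounds shown here, placing phenyl in place of 1-methylethenyl on this aromatic carbon, two ring bonds from the ring sulfur, gives a 5.0-fold lower number from compound 1 to compound 4 (0.70 log units; beyond the scatter) and is the first step here that lies beyond the scatter. The earlier compounds shown here, whose values could not be told apart, did not show that a change of group at this place can move the read-out. No data given here account for this step.

The compounds shown leave open whether cyclohexyl, or a phenyl carrying an amine or a carboxylic acid, on this carbon would give a number like that of compound 4.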